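The source may hold more compounds than are shown below. What is called first, only, known or untested is meant among the compounds shown, and "the series" means these compounds.

Measured compounds:
compound 1 `CC(C)[C@H](NC(=O)COc1cccc2ccccc12)C(=O)N[C@@H](CC(=O)O)C(=O)COc1cccc(C(F)(F)F)c1`, 16600 nM in a functional assay with Homo sapiens as the target; on this read-out lower numbers stand for stronger inhibition and higher numbers for weaker inhibition
compound 2 `CC(C)[C@H](NC(=O)COc1cccc2ccccc12)C(=O)N[C@@H](CC(=O)O)C(=O)COc1ccc(F)cc1F`, 17600 nM in this assay

Compound 1 gives the lowest of the two numbers in this assay; its nearest neighbour is compound 2, and the step of a 1.1-fold higher number from compound 1 to compound 2 (0.03 log units; within the scatter) lies within the scatter, so no order between the two can be read. Compound 3 `CC(C)[C@H](NC(=O)COc1cccc2ccccc12)C(=O)N[C@@H](CC(=O)O)C(=O)COc1c(F)cccc1F` differs from compound 1 by 2,6-difluorophenyl in place of 3-(trifluoromethyl)phenyl on an oxygen on a saturated carbon. Going by the values given here, the only measured step that bears on this change is the exchange at the same oxygen on a saturated carbon, 2,4-difluorophenyl in place of 3-(trifluoromethyl)phenyl, which gave a 1.1-fold higher number from compound 1 to compound 2 (0.03 log units; within the scatter); a move of the 3-(trifluoromethyl)phenyl to a difluorophenyl therefore left the number unchanged within the scatter in the one case where it was measured. Among the compounds with values here, no compound with a 2,6-difluorophenyl at this position has been measured, so the expectation rests on that single comparison. Compound 3 is expected to stand close to compound 1, with a 1.0-fold higher number from compound 1 to compound 3 (0.01 log units; within the scatter), a step of no size beyond the scatter. The estimate for compound 3 in this assay is 17000 nM, with a range from 7000 nM to 40000 nM.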

Compound 3, half-maximal inhibitory concentration: > 100000 nM
Compound 3: a limit, no number; the forecaster's own chance of this, stated with the estimate: 10%; middle value at least 5.8-fold (0.76 log units) away from the limit.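

In this assay, compound 3 gives a limit and not a number: the limit of > 100000 nM in this assay, at which 1 of the 3 values shown sits.

Even so, the change to 2,6-difluorophenyl on this oxygen on a saturated carbon can be read as a step, with an at least 6.0-fold higher number from compound 1 to compound 3 (0.77 log units; beyond the scatter) and an at least 5.6-fold higher number from compound 2 to compound 3 (0.75 log units; beyond the scatter). The earlier pair, with a 1.1-fold higher number from compound 1 to compound 2 (0.03 log units; within the scatter), gave no sign that this position distinguishes between such groups, whereas compounds 2 and 3 now show that two difluorophenyl groups with the fluorines placed differently are not interchangeable here, and that a difluorophenyl group as such does not set the read-out.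

Going by these compounds, since the value of compound 3 is a limit, both steps give only a lower bound on the size of the change, and how far compound 3 lies beyond the limit stays unknown. On these data alone, it also stays open whether the 2,6-pattern of fluorines is specific in this respect, which a monofluorophenyl, a dichlorophenyl or a phenyl ring carrying an amine at this oxygen would help to separate.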